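Aryl change on the sulfonyl sulfur: compound 3

The source may report more compounds than this note shows. Statements on the series, on what has been measured and on what is new or still open speak of the compounds shown alone.

Of the two numbers measured in a functional assay on MCF7 cells (Homo sapiens) for antiproliferative activity, read by MTT assay, with a stated time of 48 h (on this read-out lower numbers stand for stronger inhibition and higher numbers for weaker inhibition), compound 2 `O=C(/C=C/c1cn(S(=O)(=O)c2cccc3ccccc23)c2ccccc12)c1ccncc1` gives 58000 nM and compound 1 `O=C(/C=C/c1cn(S(=O)(=O)c2ccc(Cl)cc2)c2ccccc12)c1ccncc1` gives 37500 nM; the step of a 1.5-fold higher number from compound 1 to compound 2 (0.19 log units; within the scatter) is within the scatter, so neither compound is to be ranked above the other. Compound 3 `O=C(/C=C/c1cn(S(=O)(=O)c2cccc([N+](=O)[O-])c2)c2ccccc12)c1ccncc1` differs from compound 2 by 3-nitrophenyl in place of naphthalen-1-yl on a sulfonyl sulfur. Among the measured compounds shown here, the one measured step bears directly on this change, as it also swapped the aryl group on the sulfonyl sulfur, and it moved the number by little; no step beyond the scatter is therefore expected in this assay. Compound 3 is estimated at 45000 nM, range 20000 nM to 110000 nM, an expected step of a 1.3-fold lower number from compound 2 to compound 3 (0.11 log units; within the scatter).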

Compound 3, half-maximal inhibitory concentration: 36300 nM
The estimate for compound 3 lay 1.2-fold (0.09 log units) above the measured number; the measured number falls inside the stated range.
By their numbers in this assay, from the lowest: compounds 3, 1 and 2 (each within the scatter of the next).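

In this assay, 3-nitrophenyl on the sulfonyl sulfur gives a 1.6-fold lower number from compound 2 to compound 3 (0.20 log units; within the scatter) and a 1.0-fold lower number from compound 1 to compound 3 (0.01 log units; within the scatter). Neither step leaves the scatter, so 3-nitrophenyl, 4-chlorophenyl and naphthalen-1-yl cannot be ranked at this position, and a third aryl group has still produced no separation. No supporting data bear on this flat result.

On these data alone, whether an amine or a carboxylic acid on the aryl ring would move the number remains open. So does the effect of a simple alkyl chain in place of the aryl group on the sulfonyl sulfur.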